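The compounds below may be only part of what the source reports. "The series", "measured", "known", "first", "only" and "open" are said of these compounds alone.

Of the compounds shown here, three sharing one core have been measured in an assay on HEK293 cells for displacement of a labelled ligand from 5-hydroxytryptamine receptor 7 (Homo sapiens), read by radioligand binding, with a stated time of 1 h; on this read-out lower numbers stand for stronger inhibition and higher numbers for weaker inhibition. Compound 1 `CN1CCN(c2nc(N)nc(COc3ccccc3)n2)CC1` gives 9530 nM. Compound 2 `Cc1ccccc1OCc1nc(N)nc(N2CCN(C)CC2)n1`, which carries a 2-methylphenyl on the oxygen, gives 514 nM, and compound 3 `Cc1ccc(OCc2nc(N)nc(N3CCN(C)CC3)n2)cc1`, which carries a 4-methylphenyl there, gives 16100 nM. Among these three numbers compound 3 stands highest; its number sits close to that of compound 1, while compound 2 lies far below it.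

The next compound, compound 4 `CN1CCN(c2nc(N)nc(COc3ccc(Cl)cc3Cl)n2)CC1`, differs from compound 3 in one place: 2,4-dichlorophenyl in place of 4-methylphenyl on an oxygen on a saturated carbon. Among the measured compounds shown here, the phenyl on the oxygen is thus changed again, and the earlier steps show how much this place matters. The step of a 19-fold lower number from compound 1 to compound 2 (1.27 log units; beyond the scatter) was large, while the step of a 1.7-fold higher number from compound 1 to compound 3 (0.23 log units; within the scatter) stayed within the scatter, and the step of a 31-fold higher number from compound 2 to compound 3 (1.50 log units; beyond the scatter) was large as well. For the measured compounds named here, the 2,4-dichlorophenyl carries groups at both positions that were tried one at a time with methyl, so some of the gain seen for compound 2 may return, though chlorine is not methyl and no compound here shows chlorine. A clear drop in the number from compound 3 is therefore expected, as the step of an 11-fold lower number from compound 3 to compound 4 (1.03 log units; beyond the scatter) expresses. For compound 4 the expected value in this assay is 1500 nM, with a range from 300 nM to 8000 nM.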

Compound 4, inhibition constant: 3800 nM
Estimate against measurement, compound 4: 2.5-fold (0.40 log units) below; the range from low to high includes it.
By their numbers in this assay, from the lowest: compound 2; then compound 4; then compounds 1 and 3 (each within the scatter of the next).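

In this assay, the 2,4-dichlorophenyl shows that a phenyl carrying chlorine, not only one carrying methyl, can lower the number at this place: the change brings a 2.5-fold lower number from compound 1 to compound 4 (0.40 log units; beyond the scatter) and also a 4.2-fold lower number from compound 3 to compound 4 (0.63 log units; beyond the scatter) when it replaces the 4-methylphenyl. It does not match the 2-methylphenyl, however, as a 7.4-fold higher number from compound 2 to compound 4 (0.87 log units; beyond the scatter) makes clear, so compound 2 keeps the lowest number of the four and the size of the gain depends on which groups the phenyl carries. Among these compounds, the two phenyl groups with a 2 in their names give lower numbers than the unsubstituted phenyl, whereas compound 3, with only its 4-methylphenyl, shows no such gain and goes against any idea that adding a group to the phenyl is enough.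

No measurement given here explains these differences. Still open, going by these compounds, is how much each chlorine contributes, which 2-chlorophenyl and 4-chlorophenyl compounds could separate, and whether a methoxy group or a fluorine on the phenyl would behave like methyl or chlorine on the same shared core.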